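Series notes: trimming the side chain of compound 2

The compounds below may be only part of what the source reports. "The series", "measured", "known", "first", "only" and "open" are said of these compounds alone.

Measured so far:
compound 1, `O=C(O)[C@@H]1CCCN1C(=O)CN(c1nc(Cl)nc2[nH]cnc12)C1CC1`, 26%
compound 2, `NCCCC[C@H](NC(=O)CN(c1nc(Cl)nc2[nH]cnc12)C1CC1)C(=O)OCc1ccccc1`, 35.3%
compound 3, `CC[C@H](C)[C@H](NC(=O)CN(c1ncnc2c1ncn2C1CCCCO1)C1CC1)C(=O)OCc1ccccc1`, 22.6%

In a functional assay on the whole organism (Tail, strain ICR) with Mus musculus as the target, in the tail flick test, with a stated time of 90 min, at a dose of 25 umol/kg by the oral route (a higher number here means a stronger effect of the compound at the dose given, a lower number a weaker effect), compound 2 gives the highest of the three numbers. Its nearest neighbour is compound 1, whose number is lower by an amount within the usual scatter, so the two cannot be ordered. The furthest is compound 3, whose number lies beyond the scatter below compound 2; compound 3 also carries a different core and a different ester side chain, so no single change can be read from that pair.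

Compound 4, `C[C@H](NC(=O)CN(c1nc(Cl)nc2[nH]cnc12)C1CC1)C(=O)OCc1ccccc1`, has not yet been measured. It differs from compound 2 in one place: hydrogen in place of 3-aminopropyl on a saturated chain carbon, two bonds along the chain from an amide-type nitrogen and a carbonyl carbon. For the measured compounds named here, no pair of measured compounds differs in only one place, so there is no measured step to lean on. Since compound 1 sits within the scatter of compound 2 despite a different side chain, only a small step is expected. The step is estimated at a number 7.3 percentage points lower from compound 2 to compound 4 (within the scatter), leaning downward but not clearly beyond the scatter.

Compound 4 is therefore expected to give about 28% in this assay, with a range from 16% to 40%.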

Compound 4, a percentage reported as activity, at one dose (the size of the read-out at that dose, not a potency): 44.2%
Compound 4: middle estimate off by 16.2 percentage points, on the low side; the measured number lies above the stated range.
By their numbers in this assay, from the lowest: compounds 3, 1, 2 and 4 (each within the scatter of the next, the first and the last beyond it).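

For the compounds shown here, the first one-place step falls on the saturated chain carbon, two bonds along the chain from an amide-type nitrogen and a carbonyl carbon: in this assay, hydrogen in place of 3-aminopropyl gives a number 8.9 percentage points higher from compound 2 to compound 4 (within the scatter). Read the other way, with the cut one bond further out as 4-aminobutyl to methyl, the whole amine-bearing chain can go without the read-out at this dose leaving the usual scatter, so the chain's terminal amine is not required for an effect of this size in this whole-animal test. Nothing at hand bears on why the read-out holds once the chain is gone.

With one step at this position, the compounds shown do not say whether the response follows chain length or the amine itself; an unbranched butyl chain with no amine, or a chain ending in a carboxylic acid, would separate the two. Also open, from the compounds shown here alone, is whether the same change carries over to a different ester or core, since this step was read on one benzyl ester with one core, at one dose and one time.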